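The compounds below may be only part of what the source reports. "The series", "measured", "known", "first", "only" and "open" are said of these compounds alone.

Compound 1 `Cc1cc(N2CCC(N3CCCC3C)C2)ccc1NC(=O)C1CCOCC1` carries an oxan-4-yl group on its carbonyl carbon. In an assay on CHO cells for displacement of a labelled ligand from histamine receptor H3 (Macaca mulatta) (on this read-out higher numbers stand for weaker inhibition and lower numbers for stronger inhibition), compound 1 gives 6.8 nM, and in this assay compound 2 `Cc1cc(N2CCC(N3CCCC3C)C2)ccc1NC(=O)C1CCCO1` gives 7.34 nM; the step of a 1.1-fold higher number from compound 1 to compound 2 (0.03 log units; within the scatter) shows the two compounds cannot be told apart on this read-out. Within the data shown here, compound 3 `Cc1cc(N2CC[C@H](N3CCC[C@@H]3C)C2)ccc1NC(=O)C1CCOCC1` differs from compound 1 in a different way: the two compounds have the same atoms and bonds; at least one stereo element is drawn with a configuration in one of them and without one in the other: 2 of 2 stereo elements differ; a stereocentre at a saturated ring carbon is drawn without a configuration in compound 1 and S in compound 3; a stereocentre at a saturated ring carbon is drawn without a configuration in compound 1 and S in compound 3 The only measured step concerns a change of the ring on the carbonyl carbon, not a stereocentre, so no measured step bears on this change. Fixing both stereocentres as a single drawn configuration can leave the number where it is or move it either way, and a modest shift toward a lower number is expected in this assay as a 1.5-fold lower number from compound 1 to compound 3 (0.18 log units; within the scatter). Compound 3 is therefore estimated at 4.5 nM, within a range from 1.5 nM to 15 nM.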

Compound 3, inhibition constant: 0.97 nM
Compound 3: the middle estimate sits 4.6-fold (0.67 log units) above what was measured; the measured number lies below the stated range.
By their numbers in this assay, from the lowest: compound 3; then compounds 1 and 2 (each within the scatter of the next).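

Among these compounds, the earlier pair showed only that changing the ring on the carbonyl carbon left the number within the scatter, so it said nothing about what could move it. In this assay, the stereocentres are the first place shown where a change goes beyond the scatter, with a 7.0-fold lower number from compound 1 to compound 3 (0.85 log units; beyond the scatter). With atoms and bonds the same, the step can be set against one difference alone, so the way these two saturated ring carbons are drawn matters on this read-out: the fact that one of compounds 1 and 3 is drawn with a defined configuration and the other without, at the place where they differ

The compounds shown leave open which of the two stereocentres accounts for the step and how the other configurations compare with the form drawn S at both. They also leave open whether the same step would appear with an amine or a longer chain on the carbonyl carbon in place of oxan-4-yl.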